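This account rests on a few compounds, and the source may have more. Where it says the series, first, only, none or still open, it means among the compounds named here.

In a functional assay on the whole organism (strain BALB/c) for inhibition, with Mus musculus as the target, read by paw edema, with a stated time of 4 h, at a dose of 50 mg/kg by the oral route (on this read-out lower numbers stand for less inhibition and higher numbers for more inhibition at the one dose given (going by the name of the read-out)), compound 1 `CCNc1nnc(-c2cc(-c3ccc(F)cc3F)ccc2O)s1` gives 50.2%, the highest of the three measured numbers. Compound 2 `COc1ccc(Nc2nnc(-c3cc(-c4ccc(F)cc4F)ccc3O)o2)cc1` gives 35.3%, and compound 3 `C=CCNc1nnc(-c2cc(-c3ccc(F)cc3F)ccc2O)o1` gives 36.6%; both fall beyond the scatter below compound 1. For the measured compounds named here, the one measured step, a number 1.3 percentage points higher from compound 2 to compound 3 (within the scatter), changes the group on the ring nitrogen within a core that differs from that of compound 1 and stays within the scatter. Compound 4 `C=CCNc1nnc(-c2cc(-c3ccc(F)cc3F)ccc2O)s1` keeps the core of compound 1 and differs from it by vinyl in place of methyl on a saturated chain carbon bound to a nitrogen on an aromatic ring. Going by the values given here, no measured step covers ethyl to allyl directly; the only related step suggests that changing the group on this nitrogen moves the read-out little, so compound 4 is expected to land near compound 1, with an expected step of a number 4.2 percentage points lower from compound 1 to compound 4 (within the scatter). Compound 4 is therefore estimated at 46%, within a range from 32% to 60%.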

Compound 4, a percentage reported as inhibition, in the whole organism at one dose (the size of the read-out at that dose, not a potency): 57.2%
Estimate against measurement, compound 4: 11.2 percentage points below; low and high end bracket the measured number.
By their numbers in this assay, from the lowest: compounds 2 and 3 (each within the scatter of the next); then compounds 1 and 4 (each within the scatter of the next).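

In this assay, replacing ethyl with allyl on the core of compound 1 gives a number 7 percentage points higher from compound 1 to compound 4 (within the scatter). For the compounds shown here, this is the first direct reading of this change, and it shows that on this core the extra carbon and the double bond leave the read-out within the usual scatter. Nothing available here gives a reason for this result. The compounds shown leave open how a longer chain such as butyl, or a carboxylic acid or an amine, would read in place of ethyl on this nitrogen.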